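The compounds below may be only part of what the source reports. "The series", "measured", "known", "first", "only" and "open" are said of these compounds alone.

Two compounds of a shared core carry a carbonyl on an aromatic nitrogen and have been tested in an ADME assay on HEK-293T cells (Homo sapiens) for cytotoxicity, read by MTT assay, with a stated time of 24 h; on this read-out lower numbers stand for higher toxicity in this test and higher numbers for lower toxicity in this test. Compound 1 `O=C(c1ccc(Cl)cc1)n1c(-c2cn(-c3ccccc3)nc2-c2ccc(C(F)(F)F)cc2)nc2ccccc21` gives 181000 nM in this assay. Compound 2 `Cc1ccc(-c2nn(-c3ccccc3)cc2-c2nc3ccccc3n2C(=O)c2cccc(C)c2)cc1` gives 195000 nM in this assay, and the gap between compound 2 and compound 1 lies within the scatter of repeated measurements, so the two numbers cannot be told apart; compound 2 therefore stands nowhere distinct on the two numbers shown.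

Compound 3 `Cc1ccc(-c2nn(-c3ccccc3)cc2-c2nc3ccccc3n2C(=O)c2ccc(Cl)cc2)cc1` has not yet been measured in this assay. It differs from compound 2 in one place: 4-chlorophenyl in place of 3-methylphenyl on a carbonyl carbon. The 4-chlorophenyl group that enters is the same group that compound 1 carries on its carbonyl carbon, and compound 1 sits within the scatter of compound 2.

Both measured compounds cluster at the same level, so compound 3 is expected to land there too; the step from compound 2 to compound 3 is estimated as a 1.1-fold lower number from compound 2 to compound 3 (0.02 log units; within the scatter), with no movement beyond the scatter in either direction. Compound 3 is expected to give 185000 nM in this assay, with a range from 90000 nM to 380000 nM.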

Compound 3, half-maximal cytotoxic concentration: 216000 nM
For compound 3 the middle estimate is 1.2-fold (0.07 log units) below the measured one; the measured number falls inside the stated range.
By their numbers in this assay, from the lowest: compounds 1, 2 and 3 (each within the scatter of the next).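

On the carbonyl carbon whose other neighbour is an aromatic nitrogen, 4-chlorophenyl in place of 3-methylphenyl gives a 1.1-fold higher number from compound 2 to compound 3 (0.04 log units; within the scatter) in this assay. This gives the position a direct one-place reading that compounds 1 and 2 alone could not provide, and at this position the two groups cannot be told apart. The second comparison reads a different place, where methyl in place of trifluoromethyl on an aromatic carbon, with the 4-chlorophenyl group held on the carbonyl carbon, gives a 1.2-fold higher number from compound 1 to compound 3 (0.08 log units; within the scatter), so neither single exchange separates the compounds, and nothing measured here offers an explanation for either reading.

Going by these compounds, it remains open whether a carboxylic acid on the ring attached to the carbonyl carbon, or an amine in place of that ring, would move the number beyond the scatter, and the same question stands for a methoxy group in place of methyl or trifluoromethyl on the aromatic carbon. With all three compounds at one level, the set also gives no indication of which change on the shared core, if any, would produce a clearly lower number.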